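Replacing the Nitrophenyl Group of Compound 2

The source may hold more compounds than are shown below. What is called first, only, known or untested is meant among the compounds shown, and "the series" means these compounds.

- Compound 1 `O=C(N/N=C/c1ccc([N+](=O)[O-])cc1)Nc1ccc(Oc2ccnc3[nH]ccc23)c(F)c1`: 4000 nM
- Compound 2 `O=C(N/N=C/c1ccc([N+](=O)[O-])cc1)Nc1ccc(Oc2ccnc3[nH]ccc23)cc1`: 15600 nM

In a functional assay on MCF7 cells (Homo sapiens) for antiproliferative activity, read by MTT assay, with a stated time of 72 h (a higher number here means a weaker inhibitor, a lower number a stronger inhibitor), compound 2 gives 15600 nM, the higher of the two numbers, which makes it the weaker inhibitor of the pair. Compound 3 `O=C(N/N=C/c1ccc(O)cc1Br)Nc1ccc(Oc2ccnc3[nH]ccc23)cc1` differs from compound 2 by one swap: 2-bromo-4-hydroxyphenyl in place of 4-nitrophenyl on a carbon with a double bond to nitrogen. In words, 2-bromo-4-hydroxyphenyl stands in place of 4-nitrophenyl on a carbon with a double bond to nitrogen. For the measured compounds named here, neither measured compound carries the new group, so no measured step tests this swap directly. Going by the values given here, the only guide to size is a 3.9-fold higher number from compound 1 to compound 2 (0.59 log units; beyond the scatter), a modest step from hydrogen in place of fluoro at a different place. A modest change is therefore expected here too, with only a tentative lean towards a lower number. The estimated step is a 1.7-fold lower number from compound 2 to compound 3 (0.24 log units; within the scatter). The expected value for compound 3 is 9000 nM, within an estimated range from 2500 nM to 30000 nM.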

Compound 3, half-maximal inhibitory concentration: "not active" (no number reported)
Compound 3: no number reported, so the estimate cannot be set against anything.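

For the compounds shown here, compound 3 is reported only as "not active", with no number, so no step from compound 2 to compound 3 can be read. Still open, from the compounds shown here alone, is how far 2-bromo-4-hydroxyphenyl in place of 4-nitrophenyl moves the number. No available evidence bears on this result.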